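A few compounds are considered here, and "the series" means these few. Any claim that something is new, unique, unknown or untested is made for them only; others in the source may bear on it.

In an ADME assay on MDBK cells (Bos taurus) for cytotoxicity, read by MTT assay, with a stated time of 96 h (on this read-out higher numbers stand for lower toxicity in this test and lower numbers for higher toxicity in this test), compound 1 `C/C(=N\NC(N)=O)c1ccc2[nH]c(-c3ccc(Cl)cc3)nc2c1` gives > 100000 nM as a limit of the assay, not a number. Compound 2 `C/C(=N\NC(N)=S)c1ccc2[nH]c(-c3ccc(Cl)cc3)nc2c1` gives > 100000 nM as a limit too, so both sit on the same line: the limit of > 100000 nM in this assay, at which 2 of the 2 values shown sit, and nothing more can be read from them. Among the compounds with values here, the one measured step, a step that the two limits leave unreadable from compound 1 to compound 2, therefore has no size to carry over. Compound 3 `C/C(=N\NC(N)=O)c1ccc2[nH]c(-c3ccoc3)nc2c1` differs from compound 1 by furan-3-yl in place of 4-chlorophenyl on an aromatic carbon on the shared core, furan-3-yl in place of 4-chlorophenyl on an aromatic carbon. No shift beyond the scatter is expected in this assay, and the estimated change is a number no higher from compound 1 to compound 3 (the limit leaves the size open) as a best guess. For compound 3 the expected value is 100000 nM, with an estimated range from 40000 nM to 200000 nM in all.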

Compound 3, half-maximal cytotoxic concentration: > 100000 nM
Compound 3 ended at the assay's limit (the forecaster's own chance of this, stated with the estimate: 65%); the middle value lies on the limit itself.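

In this assay compound 3 gives > 100000 nM as a limit of the assay and not a number, so no step can be read from compound 1 to compound 3. The compounds shown leave open at what concentration, if any, each becomes toxic to these cells.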